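Prenyl Chain Added to a Cinnamoyl Hydrazone: Cytotoxicity Outlook

A few compounds are considered here, and "the series" means these few. Any claim that something is new, unique, unknown or untested is made for them only; others in the source may bear on it.

Measured compounds:
Compound 1 `CCOc1ccc(/C=C/C(=O)N/N=c2/[nH]ncc3ccccc23)cc1` — in an ADME assay on THP-1 cells (Homo sapiens) for cytotoxicity, read by MTT assay, with a stated time of 72 h (on this read-out higher numbers stand for weaker inhibition and lower numbers for stronger inhibition), compound 1 gives "not determined" (no result reported).
Compound 2 `COc1ccc(/C=C/C(=O)N/N=c2/[nH]ncc3ccccc23)cc1` — in this assay compound 2 gives 437000 nM.
Compound 3 `COc1ccc(/C=C/C(=O)N[C@@H]2CONC2=O)cc1` — in this assay compound 3 gives "not determined" (no result reported).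

Of the three compounds with a measurement entry in this assay, only compound 2 carries an actual number, and that number is very high, meaning that compound 2 inhibits the cells only weakly. Compound 1 and compound 3 give no basis for comparison, so compound 2 stands alone as the single reference point.

The step to compound 4 `CC(C)=CCOc1ccc(/C=C/C(=O)N/N=c2/[nH]ncc3ccccc23)cc1` replaces, on compound 2, 2-methylprop-1-en-1-yl in place of hydrogen on a saturated chain carbon bound to an oxygen on an aromatic ring. For the measured compounds named here, no measured pair in this set shows what such a change does in this assay, so the expectation rests on the single value of compound 2 and on the modest size of the change.

Compound 4 is expected to give a number close to that of compound 2, with the step of a 1.5-fold lower number from compound 2 to compound 4 (0.16 log units; within the scatter) expected to stay within the usual scatter, perhaps leaning toward a slightly lower number. The estimate for compound 4 in this assay is 300000 nM, within a range from 100000 nM to 800000 nM.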

Compound 4, half-maximal inhibitory concentration: 26000 nM
The estimate for compound 4 lay 12-fold (1.06 log units) above the measured number; measured number below the stated range.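

This position, the saturated chain carbon bound to an oxygen on an aromatic ring, is not a silent one: in this assay, going from methoxy to (3-methylbut-2-en-1-yl)oxy gives a 17-fold lower number from compound 2 to compound 4 (1.23 log units; beyond the scatter) in a single change. Compound 2 on its own could show only how weakly the methoxy compound inhibits, whereas this pair shows that the group on that oxygen strongly affects the read-out, and that adding 2-methylprop-1-en-1-yl, with 4 carbon atoms and no ring, is enough to produce a large step. Nothing available here explains why the number falls, so the step stands as an observation without a cause.

On these data alone, a single pair cannot separate the effects of the chain's length, its branching and its double bond, so it remains open whether a saturated 3-methylbutyl chain or a longer geranyl chain would give a similar number. As far as these compounds go, it is also open whether the lower number would hold with an amine or a carboxylic acid at the end of the chain on that oxygen.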